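Phenyl in place of chloro: expected tolerance of compound 4

The compounds below may be only part of what the source reports. "The series", "measured", "known", "first", "only" and "open" are said of these compounds alone.

Three compounds share one core and differ only in a single group on an aromatic carbon. Compound 1 `Cc1ccc(/C(COc2ccc(Br)cc2)=N\NC(N)=S)cc1` gives 13200 nM in an ADME assay on L929 cells (Mus musculus) for cytotoxicity, read by resazurin assay, with a stated time of 96 h; a lower number here means that less compound is tolerated, a higher number that more compound is tolerated. Compound 3 `NC(=S)N/N=C(/COc1ccc(Br)cc1)c1ccc(Cl)cc1` gives 25100 nM in this assay, and a 1.9-fold higher number from compound 1 to compound 3 (0.28 log units; within the scatter). For compound 2 `COc1ccc(/C(COc2ccc(Br)cc2)=N\NC(N)=S)cc1` the result in this assay is a limit of the assay, < 25400 nM, not a number. Because of the limit of < 25400 nM in this assay, at which 1 of the 3 values shown sits, the steps a step that the limit leaves unreadable from compound 1 to compound 2 and a step that the limit leaves unreadable from compound 2 to compound 3 cannot be sized. Among the compounds with values here, compound 3 therefore stands within the usual scatter of compound 1, and the only readable step of this kind is small.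

Compound 4 `NC(=S)N/N=C(/COc1ccc(Br)cc1)c1ccc(-c2ccccc2)cc1` is not yet measured. It differs from compound 3 in one place: phenyl in place of chloro on an aromatic carbon. Within the data shown here, no measured step introduces phenyl, so the only guidance is that the one readable change on this aromatic carbon, a 1.9-fold higher number from compound 1 to compound 3 (0.28 log units; within the scatter), stayed within the scatter, while the other two steps were unreadable. On that basis the step of a 1.7-fold lower number from compound 3 to compound 4 (0.22 log units; within the scatter) is expected to remain within the scatter, with no clear direction. The value of compound 4 in this assay is accordingly estimated at 15000 nM, with a range from 5000 nM to 40000 nM.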

Compound 4, half-maximal cytotoxic concentration: 22700 nM
Estimate against measurement, compound 4: 1.5-fold (0.18 log units) below; the range from low to high includes it.
By their numbers in this assay, from the lowest: compounds 1, 4 and 3 (each within the scatter of the next).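

In this assay, phenyl in place of chloro brings six heavy atoms and a six-membered aromatic ring of carbon only where one chlorine stood, and it gives a 1.1-fold lower number from compound 3 to compound 4 (0.04 log units; within the scatter). Phenyl in place of methyl gives a 1.7-fold higher number from compound 1 to compound 4 (0.24 log units; within the scatter), so both readable steps to the new compound stay within the scatter. The earlier compounds tested only single small groups on this aromatic carbon, para to a large group, whereas compound 4 shows that a whole added ring at this place still leaves the number within the scatter of compound 1 and compound 3, and the steps that involve compound 2 cannot be read because its value is a limit of the assay and not a number: the limit of < 25400 nM in this assay, at which 1 of the 4 values shown sits.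

The compounds shown leave open whether this place would stay as undemanding with a group of another kind, such as an amine, a carboxylic acid or a longer chain. They also leave open whether the same would hold for phenyl if the rest of the shared core were changed.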